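Amino restored on the carbonyl with the chloro-trifluoromethyl aryl

This account rests on a few compounds, and the source may have more. Where it says the series, first, only, none or still open, it means among the compounds named here.

Compound 1 `COc1cc(-c2nn(-c3cccc(NC(=O)Nc4ccc(Cl)c(Cl)c4)c3)cc2-c2ccncc2)ccc1Cl` gives 388 nM in a functional assay on RPMI-8226 cells (Homo sapiens) for inhibition, read by sulforhodamine B assay, with a stated time of 48 h; a lower number here means a stronger inhibitor of growth, a higher number a weaker inhibitor of growth. For the measured compounds named here, compound 2 `COc1cc(-c2nn(-c3cccc(NC(=O)c4ccc(Cl)c(C(F)(F)F)c4)c3)cc2-c2ccncc2)ccc1Cl` gives 1620 nM in this assay, the higher of the two numbers measured so far; the step of a 4.2-fold higher number from compound 1 to compound 2 (0.62 log units; beyond the scatter) changed both the aryl group and the linkage on the carbonyl carbon at once. Compound 3 `COc1cc(-c2nn(-c3cccc(NC(=O)Nc4ccc(Cl)c(C(F)(F)F)c4)c3)cc2-c2ccncc2)ccc1Cl` differs from compound 2 by (4-chloro-3-(trifluoromethyl)phenyl)amino in place of 4-chloro-3-(trifluoromethyl)phenyl on a carbonyl carbon, restoring the amino linkage of compound 1 while keeping the aryl group of compound 2. Going by the values given here, only the step of a 4.2-fold higher number from compound 1 to compound 2 (0.62 log units; beyond the scatter) bears on this. It mixes two changes, and the data do not separate the share of each. A lower number is expected for compound 3, an estimated step of a 2.9-fold lower number from compound 2 to compound 3 (0.47 log units; beyond the scatter). The estimate for compound 3 is 550 nM, between 200 nM and 1500 nM.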

Compound 3, concentration for 50% growth inhibition: 868 nM
Beside the measured number, compound 3's estimate is 1.6-fold (0.20 log units) below it; the range from low to high includes it.
By their numbers in this assay, from the lowest: compound 1; then compounds 3 and 2 (each within the scatter of the next).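

Holding the 4-chloro-3-(trifluoromethyl)phenyl group fixed, amino on the carbonyl carbon gives a 1.9-fold lower number from compound 2 to compound 3 (0.27 log units; within the scatter), so this linkage change alone is not resolved from the scatter. Holding the amino linkage fixed, trifluoromethyl in place of chloro on an aromatic carbon gives a 2.2-fold higher number from compound 1 to compound 3 (0.35 log units; beyond the scatter), the only single change here that clears the scatter, though modestly. No measurement available accounts for either step.

Open, on these data alone, is how a nitrile, a methyl or a bromo on that aromatic carbon would compare. Also open, as far as these compounds go, is how a methylene on the carbonyl carbon would compare with amino.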